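Phenyl to benzyl on the ring amine nitrogen: compound 3

The source may hold more compounds than are shown below. What is called first, only, known or untested is meant among the compounds shown, and "the series" means these compounds.

Measured compounds:
compound 1 `CN(C)/C=C/N1CCN(CC(=O)Nc2ccc(-c3nc(-c4ccccc4)c(-c4ccccc4)n3C)cc2)CC1`: 11.1%
compound 2 `Cn1c(-c2ccc(NC(=O)CN3CCN(c4ccccc4)CC3)cc2)nc(-c2ccccc2)c1-c1ccccc1`: 37.7%

In a functional assay on MCF7 cells (Homo sapiens) for cytotoxicity, read by MTT assay, with a stated time of 24 h, tested at 6.4 ug/mL (on this read-out lower numbers stand for a weaker effect and higher numbers for a stronger effect at the one concentration tested), compound 1 gives 11.1% and compound 2 gives 37.7%. Among the compounds with values here, compound 2 stands highest of the two numbers; its nearest neighbour is compound 1, separated by the one measured step, a number 26.6 percentage points higher from compound 1 to compound 2 (beyond the scatter), which lies beyond the scatter.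

Compound 3 `Cn1c(-c2ccc(NC(=O)CN3CCN(Cc4ccccc4)CC3)cc2)nc(-c2ccccc2)c1-c1ccccc1` differs from compound 2 by benzyl in place of phenyl on an amine nitrogen in a ring. The step from compound 1 to compound 2 bears on it only in that it touches the same amine nitrogen in a ring: there the exchange was 2-(dimethylamino)ethenyl for phenyl, and it was modest. Within the data shown here, no measured step exchanges phenyl for benzyl, so the direction is open. The expectation is a step within the scatter, with a wide range on either side. The expected step is a number 7.7 percentage points lower from compound 2 to compound 3 (within the scatter). For compound 3 the estimate in this assay is 30%, between 10% and 52%.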

Compound 3, a percentage reported as activity, at one concentration (the size of the read-out at that concentration, not a potency): 23.8%
Compound 3: middle estimate off by 6.2 percentage points, on the high side, within the range that was stated.
By their numbers in this assay, from the lowest: compound 1; then compound 3; then compound 2.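

In this assay, exchanging phenyl for benzyl on the amine nitrogen in a ring still moves the read-out, giving a number 13.9 percentage points lower from compound 2 to compound 3 (beyond the scatter), although both groups carry one six-membered aromatic ring of carbon only. The presence of that ring therefore does not by itself set the result at this position, yet benzyl also stands clear of 2-(dimethylamino)ethenyl, with a number 12.7 percentage points higher from compound 1 to compound 3 (beyond the scatter), so that both ring-bearing groups lie above the non-aromatic group in these three compounds. No available measurement gives a reason for either step.

From the compounds shown here alone, whether a 2-phenylethyl group, a phenyl ring bearing fluorine or a methoxy group, or a plain methyl on this nitrogen would fit the same order remains open. Each compound is also read at a single concentration, so these numbers show only a stronger or weaker effect at that concentration and nothing further.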